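A few compounds are considered here, and "the series" means these few. Any claim that something is new, unique, unknown or untested is made for them only; others in the source may bear on it.

Measured so far in a functional assay (trachea) with Rattus norvegicus as the target; on this read-out lower numbers stand for lower potency and higher numbers for higher potency (the scale is a negative logarithm):
- compound 1 `CC1(C)C=C(n2ccccc2=O)c2ccccc2O1`: compound 1 gives 5.05
- compound 2 `CC1(C)C=C(n2ccccc2=O)c2cc(C(=O)c3cccs3)ccc2O1`: compound 2 gives 5.84

Among the measured compounds shown here, compound 2 holds the higher of the two numbers in this assay; its only neighbour is compound 1, and the step of a number 0.79 log units higher from compound 1 to compound 2 (beyond the scatter) is the one measured step. The unmeasured compound 3 `CC1(C)C=C(n2ccccc2=O)c2cc(C(=O)c3ccco3)ccc2O1` keeps the carbonyl of compound 2 and changes what sits on it: furan-2-yl in place of thiophen-2-yl on a carbonyl carbon. For the measured compounds named here, no measured step touches this place, so the sole step known, which brings in the whole (thiophen-2-yl)carbonyl group, bears on it only by showing that a carbonyl carrying a five-membered aromatic ring with one hetero atom raises the number in this assay. The step from compound 2 to compound 3 exchanges one such ring for another of the same size and count of hetero atoms, so no shift beyond the scatter is expected, in either direction; the expected step is a number 0.09 log units lower from compound 2 to compound 3 (within the scatter). Compound 3 is therefore estimated at 5.75, with a range from 5.35 to 6.15.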

Compound 3, logarithm of the reciprocal of the active concentration, log(1/C): 5.92
Beside the measured number, compound 3's estimate is 0.17 log units below it; the range from low to high includes it.
By their numbers in this assay, from the lowest: compound 1; then compounds 2 and 3 (each within the scatter of the next).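

In this assay, furan-2-yl in place of thiophen-2-yl on a carbonyl carbon gives a number 0.08 log units higher from compound 2 to compound 3 (within the scatter), so at this place the compounds shown do not separate a ring holding sulfur from one holding oxygen. (Furan-2-yl)carbonyl in place of hydrogen on an aromatic carbon gives a number 0.87 log units higher from compound 1 to compound 3 (beyond the scatter), so the rise over compound 1 is no longer tied to a single group: it now appears with both the (thiophen-2-yl)carbonyl and the (furan-2-yl)carbonyl group, and neither compound goes against it. Nothing at hand explains either the rise over compound 1 or the closeness of compound 2 and compound 3.

The compounds shown leave open whether the rise depends on the aromatic ring or comes with the carbonyl alone, a question that a simple acetyl group on the same aromatic carbon would address. They also leave open how far the ring on the carbonyl can be changed, for example to phenyl or pyridin-2-yl, and whether a carbonyl is needed at all, as against a sulfonyl or a methylene link to the same ring.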